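A few compounds are considered here, and "the series" means these few. Any claim that something is new, unique, unknown or untested is made for them only; others in the source may bear on it.

Compound 1 `Cc1nc(C)c(CN2CCN(c3cccc4[nH]c(-c5ccc(C(C)(C)C)cc5)nc34)CC2)s1`, compound 2 `CCc1nc(C)c(CN2CCN(c3cccc4[nH]c(-c5ccc(C(C)(C)C)cc5)nc34)CC2)s1` and compound 3 `CCCn1cnc(CN2CCN(c3cccc4[nH]c(-c5ccc(C(C)(C)C)cc5)nc34)CC2)c1C` share one core and differ only in the group on the saturated chain carbon bound to the amine nitrogen in a ring. In an assay on isolated protein for displacement of a labelled ligand from Gonadotropin-releasing hormone receptor (Homo sapiens) (on this read-out lower numbers stand for stronger inhibition and higher numbers for weaker inhibition), compound 1 gives 27 nM, compound 2 gives 20 nM and compound 3 gives 12 nM. The change from compound 1 to compound 2 is methyl in place of hydrogen on a saturated chain carbon bound to an aromatic carbon; it made a 1.4-fold lower number from compound 1 to compound 2 (0.13 log units; within the scatter). The two cores of compound 1 and compound 3 differ as 5-methyl-1-propyl-1H-imidazol-4-yl in place of 2,4-dimethyl-1,3-thiazol-5-yl on a saturated chain carbon bound to an amine nitrogen in a ring, and this change made a 2.3-fold lower number from compound 1 to compound 3 (0.35 log units; beyond the scatter). From compound 2 to compound 3 the step is a 1.7-fold lower number from compound 2 to compound 3 (0.22 log units; within the scatter).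

Compound 4 `CCCCn1cnc(CN2CCN(c3cccc4[nH]c(-c5ccc(C(C)(C)C)cc5)nc34)CC2)c1C` has not yet been measured in this assay. It differs from compound 3 by methyl in place of hydrogen on a saturated chain carbon, three bonds along the chain from an aromatic nitrogen. Among the compounds with values here, this is the same kind of change as the one from compound 1 to compound 2, a methyl in place of hydrogen on a saturated chain carbon, but not the same change: in the earlier pair the carbon was bound to an aromatic carbon, whereas here it lies three bonds along the chain from an aromatic nitrogen. The earlier step, a 1.4-fold lower number from compound 1 to compound 2 (0.13 log units; within the scatter), stayed within the scatter, so a similarly small step is expected here. Compound 4 is therefore expected to give about 10 nM in this assay, meaning a step of a 1.2-fold lower number from compound 3 to compound 4 (0.08 log units; within the scatter), with a plausible range from 5 nM to 22 nM, resting on compound 3 at 12 nM.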

Compound 4, half-maximal inhibitory concentration: 46 nM
Compound 4: the middle estimate sits 4.6-fold (0.66 log units) below what was measured; the measured number lies above the stated range.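

Methyl in place of hydrogen does not carry over as one fixed step in this series, since the two cases part clearly in this assay: the same change on two cores in this assay, a 1.4-fold lower number (0.13 log units; within the scatter) from compound 1 to compound 2 and a 3.8-fold higher number (0.58 log units; beyond the scatter) from compound 3 to compound 4, 5.2-fold (0.71 log units) apart, beyond the scatter of two such steps. On the chain of compound 3, the change gives a 3.8-fold higher number from compound 3 to compound 4 (0.58 log units; beyond the scatter); set against the other two compounds, the butyl compound shows a 2.3-fold higher number from compound 2 to compound 4 (0.36 log units; beyond the scatter) and a 1.7-fold higher number from compound 1 to compound 4 (0.23 log units; within the scatter), so it keeps no gain over either of them. This does not show whether the core or the place of the added carbon sets the two steps apart, as the earlier methyl sits on a carbon bound to an aromatic carbon and the later one on a carbon three bonds along the chain from an aromatic nitrogen, and each case rests on a single pair.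

The compounds shown leave open how the number runs along the chain on this aromatic nitrogen, with an ethyl group at the short end and a pentyl group at the long end, so propyl cannot be called a turning point. They also leave open whether a branched isobutyl group or a cyclopropylmethyl group would follow the butyl group or the propyl group.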